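Acyl Group Changes and Cytotoxicity on a Shared Core

A few compounds are considered here, and "the series" means these few. Any claim that something is new, unique, unknown or untested is made for them only; others in the source may bear on it.

Compound 1 `O=C(c1ccccc1)N1N=C(c2cc3ccccc3oc2=O)CC1c1ccccc1`: 36600 nM
Compound 2 `CCC(=O)N1N=C(c2cc3ccccc3oc2=O)CC1c1ccccc1`: 9610 nM

Among the compounds with values here, in a functional assay on HepG2 cells (Homo sapiens) for cytotoxicity, read by MTT assay, with a stated time of 48 h (a lower number here means a stronger inhibitor, a higher number a weaker inhibitor), compound 2 stands at the lowest of the two numbers; its only neighbour is compound 1, and the step of a 3.8-fold lower number from compound 1 to compound 2 (0.58 log units; beyond the scatter) separates them. Compound 3 `O=C(c1ccccc1Cl)N1N=C(c2cc3ccccc3oc2=O)CC1c1ccccc1` differs from compound 2 by 2-chlorophenyl in place of ethyl on a carbonyl carbon. Within the data shown here, the one measured step that bears on this change, ethyl in place of phenyl on a carbonyl carbon, went a 3.8-fold lower number from compound 1 to compound 2 (0.58 log units; beyond the scatter), so putting an aromatic ring back at that carbonyl carbon is expected to move the number back up, toward compound 1. Compound 3 is therefore estimated at 28000 nM, with a range of 9000 nM to 90000 nM, an expected step of a 2.9-fold higher number from compound 2 to compound 3 (0.46 log units; beyond the scatter).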

Compound 3, half-maximal inhibitory concentration: 5440 nM
Beside the measured number, compound 3's estimate is 5.1-fold (0.71 log units) above it, and the stated range ends above it.
By their numbers in this assay, from the lowest: compounds 3 and 2 (each within the scatter of the next); then compound 1.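

In this assay, an aromatic ring on the carbonyl carbon does not by itself keep the number high: 2-chlorophenyl and ethyl cannot be told apart, with a 1.8-fold lower number from compound 2 to compound 3 (0.25 log units; within the scatter). What separates the two aromatic acyl groups is chloro in place of hydrogen on an aromatic carbon, with a 6.7-fold lower number from compound 1 to compound 3 (0.83 log units; beyond the scatter). Nothing available accounts for this effect of the chloro group.

On these data alone, whether a methoxy group or an amine on that ring would act as chloro does remains open. So does how a chain longer than ethyl would compare.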